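Swapping a Benzyl Arm for an Aminoethyl Chain

The source may report more compounds than this note shows. Statements on the series, on what has been measured and on what is new or still open speak of the compounds shown alone.

Compound 1 `O=C(NCc1ccc(F)cc1)c1nc(Br)c2cccnc2c1NCc1ccccc1` — a functional assay on HCT-116 cells (Homo sapiens) for cytotoxicity, read by MTT assay, with a stated time of 72 h; a lower number here means a stronger inhibitor, a higher number a weaker inhibitor: > 20000 nM
Compound 2 `N[C@H]1CC[C@H](Nc2c(C(=O)NCc3ccc(Oc4ccccc4)cc3)nc(Br)c3cccnc23)CC1` — "not determined" (no result reported)
Compound 3 `CS(=O)(=O)NCCCN(c1nc(C(=O)NCc2ccc(F)cc2)c(O)c2ncccc12)S(C)(=O)=O` — 15000 nM

Compound 1 gives only a limit in this assay, the limit of the limit of > 20000 nM in this assay, at which 1 of the 3 values shown sits, so no single number is known for it. Going by the values given here, compound 3 is the one compound here with a measured value, and compound 2 has none at all. Compound 4 `NCCNc1c(C(=O)NCc2ccc(F)cc2)nc(Br)c2cccnc12` differs from compound 1 by aminomethyl in place of phenyl on a saturated chain carbon bound to a nitrogen on an aromatic ring. No measured step between any two of these compounds is available, so the size of the change cannot be read from data; the expected step of an at least 1.3-fold lower number from compound 1 to compound 4 (0.12 log units; that floor lies within the scatter) is small. Compound 4 is estimated at 15000 nM, with a range from 4000 nM to 60000 nM.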

Compound 4, half-maximal inhibitory concentration: > 20000 nM
Compound 4 gave a limit, no number (the forecaster's own chance of this, stated with the estimate: 45%); middle value at least 1.3-fold (0.12 log units) from the limit.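

Compound 1 and compound 4 each give only a limit in this assay, so no step between them can be read: the limit of > 20000 nM in this assay, at which 2 of the 4 values shown sit.

The compounds shown leave open how 2-aminoethyl in place of benzyl shifts the number in this assay.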